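The source may report more compounds than this note shows. Statements on the series, on what has been measured and on what is new or still open speak of the compounds shown alone.

The compounds share the core of compound 1 `O=C(COCc1ccccc1)N1CCN(c2ccccc2)CC1`, which is examined in an in vitro ADME assay on microsomes from liver (Homo sapiens) for metabolic stability; on this read-out lower numbers stand for slow clearance and higher numbers for fast clearance. For compound 1 the entry reads "not determined" (no result reported), so it offers no reference value. Compound 2 `O=C(COCc1ccccc1)N1CCN(c2ccccc2Cl)CC1` gives 540 mL.min-1.g-1, and compound 3 `O=C(COCc1ccccc1)N1CCN(c2ccc(Cl)cc2Cl)CC1` gives 450 mL.min-1.g-1. Among the compounds with values here, these two numbers are the only ones available, and they do not separate: the one measured step is a 1.2-fold lower number from compound 2 to compound 3 (0.08 log units; within the scatter). Compound 3 thus stands level with compound 2 within the scatter.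

Compound 4 `O=C(COCc1ccccc1)N1CCN(c2cc(Cl)ccn2)CC1` has not yet been measured in this assay. It carries 4-chloropyridin-2-yl in place of 2,4-dichlorophenyl on an amine nitrogen in a ring. The measured step bears on this change only in part. Within the data shown here, it covers a chloro in place of hydrogen on an aromatic carbon, and no measured compound has an aromatic ring with a hetero atom, so the data give no direct precedent for that part of the change. A small move toward slower clearance is expected, though it may not clear the scatter, and this expectation is a weakly supported one. The expected step is a 1.6-fold lower number from compound 3 to compound 4 (0.21 log units; within the scatter). For compound 4 the estimated value is 280 mL.min-1.g-1, with an expected range from 120 mL.min-1.g-1 to 560 mL.min-1.g-1.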

Compound 4, intrinsic clearance in microsomes: 130 mL.min-1.g-1
For compound 4 the middle estimate is 2.2-fold (0.33 log units) above the measured one, within the range that was stated.
By their numbers in this assay, from the lowest: compound 4; then compounds 3 and 2 (each within the scatter of the next).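

In this assay, the place on the amine nitrogen in a ring proved able to move the read-out beyond the scatter: 4-chloropyridin-2-yl in place of 2,4-dichlorophenyl gives a 3.5-fold lower number from compound 3 to compound 4 (0.54 log units; beyond the scatter), and in place of 2-chlorophenyl it gives a 4.2-fold lower number from compound 2 to compound 4 (0.62 log units; beyond the scatter). Within the data shown here, the only earlier step at this place, a chloro in place of hydrogen on the aromatic ring, stayed within the scatter as a 1.2-fold lower number from compound 2 to compound 3 (0.08 log units; within the scatter), so compound 4, the first compound here with a hetero atom in that aromatic ring, is also the first to stand apart from the others, and it has the lowest number of the three. No measurement at hand explains this drop.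

The change from compound 3 to compound 4 replaces a ring carbon with nitrogen and removes a chloro at once, and the compounds shown do not tell these two parts apart. As far as these compounds go, it also stays open how the read-out would respond to a pyridin-2-yl group without the chloro, to a pyrimidine ring, or to a methoxy or nitrile group in place of the chloro on the pyridine ring.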